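Aryl amine variation on the shared core

This account rests on a few compounds, and the source may have more. Where it says the series, first, only, none or still open, it means among the compounds named here.

Measured in a functional assay on HeLa cells (Homo sapiens) for inhibition, read by sulforhodamine B assay; a higher number here means a weaker inhibitor, a lower number a stronger inhibitor:
Compound 1 `CCCc1ccc(NC2=CC(=O)c3nc4n(c3C2=O)[C@H]2OC[C@@H](O)[C@H]2OC4)cc1`: 4990 nM
Compound 2 `CCOc1ccc(NC2=CC(=O)c3c(nc4n3[C@H]3OC[C@@H](O)[C@H]3OC4)C2=O)cc1`: 14400 nM

Compound 1 stands at the lowest of the two numbers in this assay; compound 2 sits higher, and that gap lies beyond the usual scatter. The two differ at the group on the amine nitrogen, so nothing else in the pair varies.

Compound 3 `O=C1C=C(Nc2cccc(Cl)c2)C(=O)c2c1nc1n2[C@H]2OC[C@@H](O)[C@H]2OC1` has not yet been measured in this assay. It differs from compound 1 as follows: 3-chlorophenyl in place of 4-propylphenyl on an amine nitrogen. Among the measured compounds shown here, no pair of measured compounds shares this exact change, so the size of its effect cannot be read from the numbers so far; the only measured comparison, compound 1 against compound 2, involves a different group.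

For compound 3 a step of a 1.0-fold higher number from compound 1 to compound 3 (0.00 log units; within the scatter) is expected, no direction beyond the scatter. Compound 3 is therefore estimated at 5000 nM, with a range of 1500 nM to 16000 nM.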

Compound 3, half-maximal inhibitory concentration: 6040 nM
Estimate against measurement, compound 3: 1.2-fold (0.08 log units) below; the range from low to high includes it.
By their numbers in this assay, from the lowest: compounds 1 and 3 (each within the scatter of the next); then compound 2.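

In this assay, putting 3-chlorophenyl in place of 4-propylphenyl on the amine nitrogen gives a 1.2-fold higher number from compound 1 to compound 3 (0.08 log units; within the scatter), so compounds 1 and 3 cannot be told apart in this assay. Among the compounds shown here, this is the first sign that the group at this position can change in both its substituent and the substituent's place on the ring without a step beyond the scatter, although this single pair sets no general rule. No data shown here bear on why the two compounds read alike.

On these data alone, it remains open whether 4-chlorophenyl would read like 3-chlorophenyl, which would separate the effect of the chlorine from that of its place on the ring. Also open, as far as these compounds go, is whether a carboxylic acid or an amine on the phenyl ring, or a plain alkyl chain in place of the ring, would give a step beyond the scatter.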